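The compounds below may be only part of what the source reports. "The series", "measured", "known", "first", "only" and "open" are said of these compounds alone.

- Compound 1 `COc1cc(C(=O)c2sc(-c3ccc(Br)cc3)cc2N)cc(OC)c1OC`: 150 nM
- Compound 2 `COc1ccc(-c2cc(N)c(C(=O)c3cc(OC)c(OC)c(OC)c3)s2)cc1OC`: 72 nM
- Compound 3 `COc1cc(C(=O)c2sc(-c3ccsc3)cc2N)cc(OC)c1OC`: 3.7 nM

In a functional assay on FM3A cells (Mus musculus) for antiproliferative activity (a higher number here means a weaker inhibitor, a lower number a stronger inhibitor), compound 3 has the lowest number of the three, 3.7 nM. Compound 4 `COc1cc(C(=O)c2sc(-c3ccc(C(F)(F)F)cc3)cc2N)cc(OC)c1OC` carries 4-(trifluoromethyl)phenyl in place of thiophen-3-yl on an aromatic carbon, next to the ring sulfur: 4-(trifluoromethyl)phenyl in place of thiophen-3-yl on an aromatic carbon. Two large measured steps bear on this change, a 41-fold lower number from compound 1 to compound 3 (1.61 log units; beyond the scatter) and a 19-fold lower number from compound 2 to compound 3 (1.29 log units; beyond the scatter). Both run towards thiophen-3-yl, whereas compound 4 leaves it for a substituted phenyl ring. The step between the two phenyl compounds is only modest, a 2.1-fold lower number from compound 1 to compound 2 (0.32 log units; beyond the scatter). A large step to a higher number is therefore expected in this assay. The expected change is a 35-fold higher number from compound 3 to compound 4 (1.55 log units; beyond the scatter). For compound 4 the estimated value is 130 nM. The expected range for compound 4 runs from 40 nM to 400 nM.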

Compound 4, half-maximal inhibitory concentration: 540 nM
Beside the measured number, compound 4's estimate is 4.2-fold (0.62 log units) below it; the whole stated range lies below it.
By their numbers in this assay, from the lowest: compound 3; then compound 2; then compound 1; then compound 4.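

At this aromatic carbon next to the ring sulfur, 4-(trifluoromethyl)phenyl gives the weakest of the four compounds in this assay, with a 150-fold higher number from compound 3 to compound 4 (2.16 log units; beyond the scatter) when it replaces thiophen-3-yl. The substituted phenyl rings also differ more than the first two suggested, with a 7.5-fold higher number from compound 2 to compound 4 (0.88 log units; beyond the scatter) against the 3,4-dimethoxyphenyl ring and a 3.6-fold higher number from compound 1 to compound 4 (0.56 log units; beyond the scatter) for trifluoromethyl in place of bromo. No supporting measurement accounts for these differences.

From the compounds shown here alone, it remains open whether the low number of compound 3 is particular to thiophen-3-yl or extends to thiophen-2-yl or furan-3-yl. Going by these compounds, how an unsubstituted phenyl ring would compare at this position also remains open.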